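A ring in place of a chain on nitrogen

The compounds below may be only part of what the source reports. "The series", "measured", "known", "first", "only" and "open" are said of these compounds alone.

In a physicochemical assay for solubility, read by chemiluminescence (on this read-out lower numbers stand for lower solubility and higher numbers for higher solubility), compound 2 `COCC(C)N(CC(=O)Nc1cc(F)cc(F)c1)C(=O)c1ccc(-c2ccccn2)cc1` gives 58 ug/mL and compound 1 `O=C(CN(C(=O)c1ccc(-c2ccccn2)cc1)C1CCOCC1)Nc1cc(F)cc(F)c1` gives 99 ug/mL so the two lie within the scatter of each other. Compound 3 `O=C(CN(C(=O)c1ccc(-c2ccccn2)cc1)C1CCOC1)Nc1cc(F)cc(F)c1` has oxolan-3-yl in place of 1-(methoxymethyl)ethyl on an amide-type nitrogen. Going by the values given here, the one measured step that bears on this is a 1.7-fold lower number from compound 1 to compound 2 (0.23 log units; within the scatter) where 1-(methoxymethyl)ethyl replaces oxan-4-yl at the same place. The estimated move is a 1.4-fold higher number from compound 2 to compound 3 (0.14 log units; within the scatter) and no step beyond the scatter is expected. For compound 3 the expected value is 80 ug/mL with a range from 40 ug/mL to 160 ug/mL in repeat measurements.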

Compound 3, solubility: 102 ug/mL
Beside the measured number, compound 3's estimate is 1.3-fold (0.11 log units) below it; measured number inside the range.
By their numbers in this assay, from the lowest: compounds 2, 1 and 3 (each within the scatter of the next).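

In this assay the five-membered oxolan-3-yl on the amide-type nitrogen gives a 1.8-fold higher number from compound 2 to compound 3 (0.25 log units; within the scatter) against the open chain 1-(methoxymethyl)ethyl. Against the ring oxan-4-yl it gives a 1.0-fold higher number from compound 1 to compound 3 (0.01 log units; within the scatter). This place now carries two different rings and a chain, and the numbers separate none of them, since every step among the three stays within the scatter. Nothing measured on hand offers a reason for these numbers. Still open, as far as these compounds go, is how an amine or a carboxylic acid on this nitrogen would read, and whether any group here gives a step beyond the scatter.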